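The source may report more compounds than this note shows. Statements on the series, on what has been measured and on what is new or still open speak of the compounds shown alone.

Measured so far:
- compound 1, `CCCCCCCc1cc2c(=O)n(CC#N)cnc2s1`: > 100 ug/mL
- compound 2, `CCCCCc1cc2c(=O)n(CC3CC3)cnc2s1`: > 100 ug/mL
- compound 3, `CCCCCCCc1cc2c(=O)n(CC3CC3)cnc2s1`: > 100 ug/mL

Each of these three entries is a limit of the assay, not a number. In an ADME assay on A549 cells (Homo sapiens) for cytotoxicity, read by MTT assay, with a stated time of 11 days (a lower number here means a stronger inhibitor of growth, a higher number a weaker inhibitor of growth), compound 3 gives > 100 ug/mL, which is only a limit. For the measured compounds named here, all of the values so far sit at the limit of > 100 ug/mL in this assay, at which 3 of the 3 values shown sit, so none of the measured steps can be read as a size: a step that the two limits leave unreadable from compound 1 to compound 3 and a step that the two limits leave unreadable from compound 2 to compound 3 both stay hidden behind the two limits.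

Compound 4, `CCCCCCCc1cc2c(=O)n(CCCBr)cnc2s1`, is the next compound to be measured in this assay. It differs from compound 3 in one place: 2-bromoethyl in place of cyclopropyl on a saturated chain carbon bound to an aromatic nitrogen. Going by the values given here, nothing among the measured compounds shows what a change at this place does, since every step here is unreadable. Among the compounds with values here, the only guide is that all three measured compounds sit at the limit, and compound 4 is therefore expected to give a similar outcome, with the step that the limit leaves unreadable from compound 3 to compound 4 expected to be nothing beyond the scatter. Compound 4 is estimated at 120 ug/mL, within 60 ug/mL to 250 ug/mL, most likely again reported only as a limit.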

Compound 4, concentration for 50% growth inhibition: 34.2 ug/mL
Compound 4: middle estimate off by 3.5-fold (0.55 log units), on the high side; measured number outside the range, below it.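

The group at this place on the saturated chain carbon bound to an aromatic nitrogen can change the result in this assay: 2-bromoethyl in place of cyclopropyl gives an at least 2.9-fold lower number from compound 3 to compound 4 (0.46 log units; beyond the scatter), and 2-bromoethyl in place of cyano gives an at least 2.9-fold lower number from compound 1 to compound 4 (0.46 log units; beyond the scatter). Both steps start from a limit, so they set only a minimum size, while the steps among compound 1, compound 2 and compound 3 still cannot be read. Compound 4 is the only one of these compounds to give a number rather than a limit: the limit of > 100 ug/mL in this assay, at which 3 of the 4 values shown sit.

The compounds shown do not separate the part played by the bromine from that of the open chain, which a 3-chloropropyl or plain butyl group at the same place could test. Going by these compounds, it also remains open whether compound 4's stronger growth inhibition would survive with a pentyl chain in place of the longer chain on the core.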